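Para-substituent swap on a nitrofuranyl chalcone series

The source may hold more compounds than are shown below. What is called first, only, known or untested is meant among the compounds shown, and "the series" means these compounds.

Compound 3 `O=C(/C=C/c1ccc([N+](=O)[O-])o1)c1ccc(OCc2ccc(F)cc2)cc1`: 430000 nM
Compound 1 `O=C(/C=C/c1ccc([N+](=O)[O-])o1)c1ccccc1`: 444000 nM
Compound 2 `O=C(/C=C/c1ccc([N+](=O)[O-])o1)c1ccc(Cl)cc1`: 558000 nM

In a toxicity assay on Vero cells (Chlorocebus sabaeus) for cytotoxicity (on this read-out lower numbers stand for higher toxicity in this test and higher numbers for lower toxicity in this test), compound 3 gives 430000 nM, a number that sits inside the usual scatter of the other two: a 1.0-fold lower number from compound 1 to compound 3 (0.01 log units; within the scatter) and a 1.3-fold lower number from compound 2 to compound 3 (0.11 log units; within the scatter). Compound 4 `O=C(/C=C/c1ccc([N+](=O)[O-])o1)c1ccc(N2CCCCC2)cc1` differs from compound 3 by piperidin-1-yl in place of (4-fluorobenzyl)oxy on an aromatic carbon. Among the compounds with values here, no measured step covers this exact exchange; the closest are the two steps just named, which show that swapping the group on that aromatic carbon between hydrogen, chloro and (4-fluorobenzyl)oxy left this assay unmoved beyond the scatter. The expectation is therefore a 1.0-fold higher number from compound 3 to compound 4 (0.02 log units; within the scatter), with compound 4 estimated at 450000 nM in this assay, within the range 200000 nM to 1000000 nM.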

Compound 4, half-maximal cytotoxic concentration: 349000 nM
Compound 4: the middle estimate sits 1.3-fold (0.11 log units) above what was measured; the measured number falls inside the stated range.
By their numbers in this assay, from the lowest: compounds 4, 3, 1 and 2 (each within the scatter of the next).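

Piperidin-1-yl is the first group here with a non-aromatic ring and a ring nitrogen, yet in this assay it still stays within the scatter of the earlier groups on this aromatic carbon. That holds against (4-fluorobenzyl)oxy (a 1.2-fold lower number from compound 3 to compound 4 (0.09 log units; within the scatter)), against hydrogen (a 1.3-fold lower number from compound 1 to compound 4 (0.10 log units; within the scatter)) and against chloro (a 1.6-fold lower number from compound 2 to compound 4 (0.20 log units; within the scatter)), so none of the four groups separates from the others. No measurement to hand explains this flat result.

On these data alone, whether a carboxylic acid or a primary amine on this aromatic carbon would also stay within the scatter in this assay remains open. So does the effect of any change elsewhere on the shared core.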